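The compounds below may be only part of what the source reports. "The series", "measured", "known", "first", "only" and "open" are said of these compounds alone.

The three measured compounds share one core bearing two aromatic rings, each carrying a hydroxyl and a methoxy group, and differ in the saturated chain on the central carbon. Compound 1 `COc1cc(C(c2ccc(O)c(OC)c2)[C@H](C)[C@H](C)CO)ccc1O` reaches only a limit in a functional assay on HL-60 cells (Homo sapiens) for cytotoxicity, read by WST assay, with a stated time of 48 h; on this read-out lower numbers stand for stronger inhibition and higher numbers for weaker inhibition: compound 1 gives > 100000 nM, which is a limit of the assay and not a number (the limit of > 100000 nM in this assay, at which 1 of the 3 values shown sits). Compound 2 `COC[C@H](C)[C@@H](C)C(c1ccc(O)c(OC)c1)c1ccc(O)c(OC)c1` gives 68000 nM in this assay, and compound 3 `COc1cc(C(c2ccc(O)c(OC)c2)[C@H](CC(C)C)C(C)C)ccc1O` gives 9600 nM. Among the two numbers, compound 2 stands highest; the step of a 7.1-fold lower number from compound 2 to compound 3 (0.85 log units; beyond the scatter) lies beyond the scatter, while the step of an at least 1.4-fold lower number from compound 1 to compound 2 (0.16 log units; that floor lies within the scatter) rests on a floor that lies within it.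

Compound 4 `COC[C@@H](C)[C@H](C)C(c1ccc(O)c(OC)c1)c1ccc(O)c(OC)c1` has not yet been measured. It differs from compound 2 as follows: the two compounds have the same atoms and bonds and differ only in configuration as drawn: 2 of 2 stereo elements differ (all stereocentres are inverted: mirror images); a stereocentre at a saturated chain carbon is drawn R in compound 2 and S in compound 4; a stereocentre at a saturated chain carbon is drawn S in compound 2 and R in compound 4. Within the data shown here, none of the measured steps changes configuration alone; an at least 1.4-fold lower number from compound 1 to compound 2 (0.16 log units; that floor lies within the scatter) and a 7.1-fold lower number from compound 2 to compound 3 (0.85 log units; beyond the scatter) each swap one group for another, so neither tells how a mirror image behaves in this cell assay. Compound 4 is therefore expected to stay near compound 2, with wide uncertainty, and the estimated step is no change at the digits printed from compound 2 to compound 4 (within the scatter). Compound 4 is estimated at 68000 nM, between 25000 nM and 150000 nM.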

Compound 4, half-maximal inhibitory concentration: 73000 nM
Beside the measured number, compound 4's estimate is 1.1-fold (0.03 log units) below it, within the range that was stated.
By their numbers in this assay, from the lowest: compound 3; then compounds 2 and 4 (each within the scatter of the next). At a limit, above all of these: compound 1.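

In this assay, among these compounds, inverting both stereocentres gives a 1.1-fold higher number from compound 2 to compound 4 (0.03 log units; within the scatter), so this mirror-image pair shows no difference that can be told from the scatter, a comparison no earlier step could offer: the fact that compounds 2 and 4 differ only in the configuration as drawn. The chain on the central carbon still matters with the inverted configuration, since a 7.6-fold higher number from compound 3 to compound 4 (0.88 log units; beyond the scatter) is close in size to a 7.1-fold lower number from compound 2 to compound 3 (0.85 log units; beyond the scatter); replacing 1-isopropyl-3-methylbutyl with 2-(methoxymethyl)-1-methylpropyl thus gives a similar step for both mirror images. For compound 1 the read-out is a limit and not a number, so the comparison gives only a floor, an at least 1.3-fold lower number from compound 1 to compound 4 (0.13 log units; that floor lies within the scatter), and cannot size the swap of 2-(hydroxymethyl)-1-methylpropyl for 2-(methoxymethyl)-1-methylpropyl: the limit of > 100000 nM in this assay, at which 1 of the 4 values shown sits.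

Only one mirror-image pair is shown, which leaves open whether the mirror images of compound 1 and compound 3 would also match, and what inverting just one of the two stereocentres would do. Also open, as far as these compounds go, is how an amine or a carboxylic acid in place of the methoxy group of the 2-(methoxymethyl)-1-methylpropyl chain would read in this assay.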